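Methoxy for Chloro on the Aryl Piperazine

This account rests on a few compounds, and the source may have more. Where it says the series, first, only, none or still open, it means among the compounds named here.

The series shares a core seen in compound 1, `CC1(c2ccccc2)CC(=O)N(CC(=O)N2CCN(c3ccc(Cl)cc3)CC2)C1=O`, which in a functional assay on the whole organism (strain CD-1) with Mus musculus as the target, with a stated time of 0.5 h (on this read-out higher numbers stand for an effect only at larger amounts of compound and lower numbers for an effect already at smaller amounts), gives 300 mg/kg. For the measured compounds named here, compound 2, `CC1(c2ccccc2)CC(=O)N(CC(=O)N2CCN(c3cccc(Cl)c3)CC2)C1=O`, carries its chloro on a different aromatic carbon, and in this assay compound 2 gives "not active" (no number reported), so no single number stands for it; the two values of compound 1 and compound 2 are simply the two results at hand, with no computed step between them.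

Compound 3, `COc1cccc(N2CCN(C(=O)CN3C(=O)CC(C)(c4ccccc4)C3=O)CC2)c1`, has not been measured. It differs from compound 2 in one place: methoxy in place of chloro on an aromatic carbon. The exchange sits on an aromatic carbon of a six-membered aromatic ring of carbon only, meta to a large group, and the group that enters brings one hydrogen-bond acceptor where the chloro brought none.

Going by the values given here, since no step between measured compounds exists, the expectation for compound 3 rests on the weak showing of compound 1 and the outcome of compound 2 alone. Because compound 2 gives "not active" (no number reported), compound 3 is expected to show an effect, if any, only at large amounts, estimated at 300 mg/kg, within a range from 100 mg/kg to 1000 mg/kg.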

Compound 3, minimum effective dose: 100 mg/kg
The estimate for compound 3 lay 3.0-fold (0.48 log units) above the measured number, within the range that was stated.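

On this position, the exchange of chloro for methoxy goes with a readable effect: in this assay compound 3 gives 100 mg/kg as a number, where compound 2 has only the report "not active", so the step between these two cannot be read as a size. For the compounds shown here, the one readable step is a 3.0-fold lower number from compound 1 to compound 3 (0.48 log units; beyond the scatter) and it shows that the 3-methoxyphenyl group, on the same shared core, has an effect at a smaller amount than the 4-chlorophenyl group, although in this step the substituent and its place on the ring change together. Nothing measured here accounts for this result.

As far as these compounds go, it remains open whether the methoxy group or its place on the ring goes with the lower number, a question that 4-methoxyphenyl on the same core would help to separate. From the compounds shown here alone, it also remains open what hydroxy, ethoxy or a dimethylamino group would give on this aromatic carbon, and whether any of them would reach an effect at still smaller amounts.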